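The source may hold more compounds than are shown below. What is called first, only, known or untested is meant among the compounds shown, and "the series" means these compounds.

Measured compounds:

Compound 1 `C=CCOc1cc(OC)c(C(=O)/C=C/c2ccccc2Br)c(OCC=C)c1` gives 13900 nM in an ADME assay on Vero cells (Chlorocebus sabaeus) for cytotoxicity, read by MTT assay; on this read-out lower numbers stand for stronger inhibition and higher numbers for weaker inhibition.
Compound 2 `C=CCOc1cc(OC)c(C(=O)/C=C/c2ccncc2)c(OCC=C)c1` gives 2800 nM.
Compound 3 `C=CCOc1cc(OC)c(C(=O)/C=C/c2cc(OCC=C)c(Br)c(OCC=C)c2)c(OCC=C)c1` gives 96300 nM.

Compound 2 holds the lowest number of these three, standing a 5.0-fold lower number from compound 1 to compound 2 (0.70 log units; beyond the scatter) and a further stretch from compound 3. Compound 4 `C=CCOc1cc(OC)c(C(=O)/C=C/c2cccc(OC)c2)c(OCC=C)c1` has not yet been measured; it differs from compound 2 in one place: 3-methoxyphenyl in place of pyridin-4-yl on a double-bonded chain carbon bound to a double-bonded chain carbon. Going by the values given here, only one measured step bears on this change. Going from compound 1 to compound 2 put a pyridin-4-yl in for a carbon-only ring and gave a 5.0-fold lower number from compound 1 to compound 2 (0.70 log units; beyond the scatter). Compound 4 reverses that swap, putting a carbon-only ring back in place of the pyridin-4-yl, so a modest move to a higher number is expected, with a 2.9-fold higher number from compound 2 to compound 4 (0.46 log units; beyond the scatter). Compound 4 is therefore estimated at 8000 nM, within a range of 3000 nM to 25000 nM.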

Compound 4, half-maximal inhibitory concentration: 142000 nM
The estimate for compound 4 lay 18-fold (1.25 log units) below the measured number, and the stated range ends below it.
By their numbers in this assay, from the lowest: compound 2; then compound 1; then compounds 3 and 4 (each within the scatter of the next).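

In this assay, replacing the ring on this double-bonded chain carbon can shift the number much further than the earlier step suggested: 3-methoxyphenyl in place of pyridin-4-yl gives a 51-fold higher number from compound 2 to compound 4 (1.71 log units; beyond the scatter). Carbon-only rings are not interchangeable here either, as 3-methoxyphenyl in place of 2-bromophenyl gives a 10-fold higher number from compound 1 to compound 4 (1.01 log units; beyond the scatter). Nothing available explains either step. As far as these compounds go, the swap from pyridin-4-yl to 3-methoxyphenyl changes both the ring atoms and the attached group, so their separate shares remain unknown. From the compounds shown here alone, how a plain phenyl or a ring bearing an amine would behave at this place also remains open.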